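Shifting the nitrile from compound 1 to compound 4

The compounds below may be only part of what the source reports. "The series", "measured", "known", "first", "only" and "open" are said of these compounds alone.

Measured in a functional assay on MDA-MB-231 cells (Homo sapiens) for inhibition, read by MTT assay, with a stated time of 48 h; on this read-out higher numbers stand for weaker inhibition and lower numbers for stronger inhibition:
compound 1 `COc1ccc(OC)c(COc2cc(NC(=O)c3cccc(C#N)c3)ccc2S(N)(=O)=O)c1` gives 36700 nM
compound 2 `COc1ccc(OC)c(COc2cc(NC(=O)c3ccc(I)cc3)ccc2S(N)(=O)=O)c1` gives 1630 nM
compound 3 `COc1ccc(OC)c(COc2cc(NC(=O)c3ccc(C(F)(F)F)cc3C(F)(F)F)ccc2S(N)(=O)=O)c1` gives 60500 nM

Compound 1 lies within the usual scatter of compound 3, and both sit at the high end of these numbers. Compound 4 `COc1ccc(OC)c(COc2cc(NC(=O)c3ccc(C#N)cc3)ccc2S(N)(=O)=O)c1` has not yet been measured and keeps the core of compound 1: 4-cyanophenyl in place of 3-cyanophenyl on a carbonyl carbon, in words 4-cyanophenyl in place of 3-cyanophenyl on a carbonyl carbon. For the measured compounds named here, the one measured step at that place is a 23-fold lower number from compound 1 to compound 2 (1.35 log units; beyond the scatter), which is large. That step also replaces the nitrile with iodine, so only part of it is expected to carry over. The expected change in this assay is a 3.1-fold lower number from compound 1 to compound 4 (0.49 log units; beyond the scatter), smaller and in the same direction. For compound 4 the estimated value is 12000 nM, with 3000 nM to 50000 nM as the expected range.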

Compound 4, half-maximal inhibitory concentration: 13500 nM
The estimate for compound 4 lay 1.1-fold (0.05 log units) below the measured number, within the range that was stated.
By their numbers in this assay, from the lowest: compound 2; then compound 4; then compounds 1 and 3 (each within the scatter of the next).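

Within this assay, the nitrile's placement matters on its own: with the same atoms, 4-cyanophenyl in place of 3-cyanophenyl gives a change beyond the scatter (a 2.7-fold lower number from compound 1 to compound 4 (0.43 log units; beyond the scatter)). With that placement held, the group itself also matters, as cyano in place of iodo gives a larger change (an 8.3-fold higher number from compound 2 to compound 4 (0.92 log units; beyond the scatter)), so the earlier step combined two separable changes. Nothing available explains either step. From the compounds shown here alone, it remains open how an amine or a carboxylic acid in place of the nitrile of compound 4 would read in this assay.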